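The source may hold more compounds than are shown below. What is called first, only, known or untested is meant among the compounds shown, and "the series" means these compounds.

Compound 1 `COC(=O)c1c(-c2ccc(O)cc2)oc2ccccc2c1=O`, compound 2 `COC(=O)c1c(-c2ccc(O)cc2)oc2cc(OC)ccc2c1=O` and compound 3 `COc1cc(-c2oc3ccccc3c(=O)c2C(=O)O)cc(OC)c1OC` have been run in a functional assay on HT-29 cells (Homo sapiens) for cytotoxicity, read by MTT assay, with a stated time of 6 days; a lower number here means that less compound is needed, a higher number that more compound is needed for the effect. In this assay compound 2 gives 19.2 ug/mL. Compound 1 reaches only a limit in this assay, > 25 ug/mL. Compound 3 also stops at a limit in this assay, > 25 ug/mL. The change hydrogen in place of methoxy on an aromatic carbon gives an at least 1.3-fold higher number from compound 2 to compound 1 (0.11 log units; that floor lies within the scatter); that floor rests on (the limit of > 25 ug/mL in this assay, at which 2 of the 3 values shown sit). The difference between the cores of compound 2 and compound 3 is not broken down here. Compound 4 `COc1cc(OC)cc(-c2oc3ccccc3c(=O)c2C(=O)O)c1` arises from compound 3 by hydrogen in place of methoxy on an aromatic carbon, the same kind of change, though the place now lies on a six-membered aromatic ring of carbon only, ortho to two methoxy groups and para to a large group, rather than on a fused system, meta and para to a fused ring. The step that the limit leaves unreadable from compound 3 to compound 4 is expected to stay small. Compound 4 is estimated at 30 ug/mL in this assay, resting on the limit of compound 3.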

Compound 4, concentration for half-maximal effect: > 25 ug/mL
Compound 4 ended at the assay's limit (the forecaster's own chance of this, stated with the estimate: 70%); the middle value does not contradict the limit.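

No step can be read between compound 3 and compound 4, as both stop at a limit: the limit of > 25 ug/mL in this assay, at which 3 of the 4 values shown sit. Left open is whether hydrogen in place of methoxy on compound 3 changes the number in this assay at all.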